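The source may hold more compounds than are shown below. What is called first, only, known or untested is meant among the compounds shown, and "the series" means these compounds.

Measured so far in a functional assay on RS4-11 cells (Homo sapiens) for inhibition, read by CCK-8 assay, with a stated time of 72 h; on this read-out lower numbers stand for stronger inhibition and higher numbers for weaker inhibition:
Compound 1 `CN(C)CCCNc1ccc(S(=O)(=O)NC(=O)c2ccc(N3CCN(CC4=C(c5ccc(C(F)(F)F)cc5)CC(C)(C)CC4)CC3)cc2Oc2cnc3[nH]ccc3c2)cc1[N+](=O)[O-]`: 3.9 nM
Compound 2 `CC1(C)CCC(CN2CCN(c3ccc(C(=O)NS(=O)(=O)c4ccc(OCC5CCOCC5)c([N+](=O)[O-])c4)c(Oc4cnc5[nH]ccc5c4)c3)CC2)=C(c2ccc(C(F)(F)F)cc2)C1`: 5.9 nM

Compound 2 lies within the usual scatter of compound 1, so the two numbers cannot be ranked. For the measured compounds named here, the only measured step, a 1.5-fold higher number from compound 1 to compound 2 (0.18 log units; within the scatter), came with (oxan-4-yl)methoxy in place of (3-(dimethylamino)propyl)amino on an aromatic carbon.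

Compound 3 `CC1(C)CCC(CN2CCN(c3ccc(C(=O)NS(=O)(=O)c4ccc(OC5CCOCC5)c([N+](=O)[O-])c4)c(Oc4cnc5[nH]ccc5c4)c3)CC2)=C(c2ccc(C(F)(F)F)cc2)C1` has not yet been measured. It carries oxan-4-yl in place of (oxan-4-yl)methyl on an oxygen on an aromatic ring, a difference counted as follows: oxan-4-yl in place of (oxan-4-yl)methyl on an oxygen on an aromatic ring. Read one bond further out, this is (oxan-4-yl)methoxy to (oxan-4-yl)oxy, so the change alters the group that the measured step brought in. Going by the values given here, that step bears on the question only indirectly, since no measured pair differs in this way. Still, it stayed within the scatter, and so no shift beyond the scatter is expected here. Among the compounds with values here, the expected change is a 1.0-fold higher number from compound 2 to compound 3 (0.01 log units; within the scatter), which is no real step. Compound 3 is estimated at 6 nM in this assay, with an expected range from 2.5 nM to 15 nM for the coming measurement.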

Compound 3, half-maximal inhibitory concentration: 375 nM
For compound 3 the middle estimate is 63-fold (1.80 log units) below the measured one; measured number above the stated range.
By their numbers in this assay, from the lowest: compounds 1 and 2 (each within the scatter of the next); then compound 3.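

Placing oxan-4-yl in place of (oxan-4-yl)methyl on an oxygen on an aromatic ring gave, in this assay, a 64-fold higher number from compound 2 to compound 3 (1.80 log units; beyond the scatter), so this site, where compounds 1 and 2 could not be ranked despite their very different groups, proves highly sensitive to a small edit. The group that leaves and the group that enters both hold one six-membered non-aromatic ring with 1 hetero atom, have the same hydrogen-bond donor and acceptor counts and carry no net charge, so those shared counts do not secure the number of compound 2 in this series. Compound 3 also stands well apart from the amine-bearing compound, with (oxan-4-yl)oxy in place of (3-(dimethylamino)propyl)amino on an aromatic carbon giving a 96-fold higher number from compound 1 to compound 3 (1.98 log units; beyond the scatter), which shows that the ring alone does not match either earlier group at this site.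

The compounds shown leave open whether a longer chain such as (oxan-4-yl)ethyl on the same oxygen would keep the number of compound 2, and whether a piperidine ring in place of the oxane would alter the outcome for either link. Nothing at hand accounts for the size of this step.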